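This account rests on a few compounds, and the source may have more. Where it says the series, first, only, none or still open, it means among the compounds named here.

Measured compounds:
compound 1 `Cc1c(OCCCCOCOc2ccc(C(=O)O)cc2)ccc(C(=O)CC2CCCC2)c1O`: 46.9%
compound 2 `Cc1c(OCCCCOc2ccccc2C(=O)O)ccc(C(=O)CC2CCCC2)c1O`: 32.9%

Among the measured compounds shown here, compound 2 sits at the bottom of the two numbers read so far in an assay on HEK293 cells for positive allosteric modulation of metabotropic glutamate receptor 3 (Rattus norvegicus), read by thallium flux, with a stated time of 2.5 min; a lower number here means a smaller maximal response, a higher number a larger maximal response; its nearest neighbour is compound 1, and the step of a number 14 percentage points lower from compound 1 to compound 2 (beyond the scatter) is the only measured change and runs downward. Compound 3 `Cc1c(OCCCCOc2ccc(C(=O)O)cc2Cl)ccc(C(=O)CC2CCCC2)c1O` is the next point. Its change from compound 2 is 4-carboxy-2-chlorophenyl in place of 2-carboxyphenyl on an oxygen on a saturated carbon. The group that leaves carries its carboxylic acid as 2-carboxyphenyl; the group that enters carries it as 4-carboxy-2-chlorophenyl and adds one chlorine on the ring. For the measured compounds named here, no measured step covers a chlorine, and no measured pair has 4-carboxy-2-chlorophenyl on the oxygen on a saturated carbon, so the only guide is that compound 1, with its 4-carboxyphenoxy group, gave the higher of the two responses. On that basis a modest rise from compound 2 is expected, with wide uncertainty, as a number 9.1 percentage points higher from compound 2 to compound 3 (within the scatter). Compound 3 is estimated at 42% in this assay, expected to fall between 25% and 60%.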

Compound 3, largest response reached (reported as percent of maximum), in percent of the reference or control that the assay uses: 27.4%
Compound 3: middle estimate off by 14.6 percentage points, on the high side; the range from low to high includes it.
By their numbers in this assay, from the lowest: compounds 3 and 2 (each within the scatter of the next); then compound 1.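

In this assay, exchanging 2-carboxyphenyl for 4-carboxy-2-chlorophenyl on the oxygen on a saturated carbon gives a number 5.5 percentage points lower from compound 2 to compound 3 (within the scatter), so the two groups cannot be told apart at this place, even though the new group carries a chlorine and a differently placed carboxylic acid. Against the (4-carboxyphenoxy)methyl group of compound 1, the same new group gives a number 19.5 percentage points lower from compound 1 to compound 3 (beyond the scatter), so compound 1 now stands clear of both groups tested in its place, and 4-carboxy-2-chlorophenyl does not recover its response. Nothing at hand explains why these groups read as they do.

The exchange from compound 1 to compound 3 alters the group's linking atoms and adds the chlorine together, so the share of each in that step remains unresolved, and a plain 4-carboxyphenyl group on the same oxygen would be the direct test between them. Also open, on these data alone, is whether the carboxylic acid itself is needed at this place, which an amide or a tetrazole in its stead would address.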